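This account rests on a few compounds, and the source may have more. Where it says the series, first, only, none or still open, it means among the compounds named here.

Compound 1 `CCOC(=O)CNc1nc(Nc2ccccc2)ncc1[N+](=O)[O-]` and compound 2 `CCOC(=O)CNc1nc(Nc2ccc(Cl)cc2)ncc1[N+](=O)[O-]` share one core; the second carries a chloro where the first has hydrogen. In a functional assay on HepG2 cells (Homo sapiens) for antiproliferative activity, read by MTT assay, with a stated time of 48 h (a lower number here means a stronger inhibitor, a higher number a weaker inhibitor), compound 1 gives > 100000 nM, which is a limit of the assay. In this assay compound 2 gives > 100000 nM, also a limit. Going by the values given here, compound 3 `CCOC(=O)CN(Cc1ccccc1)c1nc(Nc2ccccc2)ncc1[N+](=O)[O-]` adds a benzyl on the nitrogen, and in this assay compound 3 gives 44400 nM, the only number among the three; the step of an at least 2.2-fold lower number from compound 1 to compound 3 (0.35 log units; beyond the scatter) shows the benzyl helps. Compound 4 `CCOC(=O)CN(Cc1ccccc1)c1nc(Nc2ccc(Cl)cc2)ncc1[N+](=O)[O-]` differs from compound 3 by chloro in place of hydrogen on an aromatic carbon. Among the compounds with values here, the only matching step, a step that the two limits leave unreadable from compound 1 to compound 2, is unreadable because of the limit of > 100000 nM in this assay, at which 2 of the 3 values shown sit, so no direction can be expected beyond the scatter. The step of a 1.1-fold lower number from compound 3 to compound 4 (0.05 log units; within the scatter) is therefore estimated as small, and compound 4 is expected near 40000 nM, within 15000 nM to 120000 nM.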

Compound 4, half-maximal inhibitory concentration: 30900 nM
Compound 4: middle estimate off by 1.3-fold (0.11 log units), on the high side, and the stated range covers the measured number.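

Going by these compounds alone, with the benzyl in place, the change from phenyl to 4-chlorophenyl can be read for the first time in this assay: the step is a 1.4-fold lower number from compound 3 to compound 4 (0.16 log units; within the scatter), so chloro shows no clear effect on this core. The benzyl step now also appears with the chloro present, as an at least 3.2-fold lower number from compound 2 to compound 4 (0.51 log units; beyond the scatter). The benzyl change therefore goes the same way on both cores: the same change on two cores in this assay, an at least 2.2-fold lower number (0.35 log units; beyond the scatter) from compound 1 to compound 3 and an at least 3.2-fold lower number (0.51 log units; beyond the scatter) from compound 2 to compound 4; the limit leaves it open whether they differ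

On these data alone, what chloro does without the benzyl stays unreadable: the limit of > 100000 nM in this assay, at which 2 of the 4 values shown sit. Also open is whether a methoxy or a bromo in place of the chloro would shift the number beyond the scatter.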